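The source may hold more compounds than are shown below. What is called first, only, known or untested is meant among the compounds shown, and "the series" means these compounds.

Series notes. Compound 1 `O=Cc1ccc(-c2cn3ccnc3c(-c3ccc4ncn(C5CCCCC5)c4c3)n2)cc1`, compound 2 `CCc1ccc(-c2cn3ccnc3c(-c3ccc4ncn(Cc5ccccc5)c4c3)n2)cc1` and compound 3 `Cc1cccc(-c2cn3ccnc3c(-c3ccc4ncn(Cc5ccccc5)c4c3)n2)c1` have been run in a functional assay on NCI-H522 cells (Homo sapiens) for inhibition, read by sulforhodamine B assay, with a stated time of 48 h, tested at 10 uM; a higher number here means more inhibition at the concentration tested (going by the name of the read-out), a lower number less inhibition. Compound 2 gives 45.9%, compound 3 gives 28.4% and compound 1 gives 25.3%. Among the measured compounds shown here, compound 3 thus stands second highest of the three numbers; its nearest neighbour is compound 1, within the scatter, and the only step beyond the scatter is a number 17.5 percentage points lower from compound 2 to compound 3 (beyond the scatter), a 3-methylphenyl in place of 4-ethylphenyl on an aromatic carbon.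

Compound 4 `O=Cc1ccc(-c2cn3ccnc3c(-c3ccc4ncn(Cc5ccccc5)c4c3)n2)cc1` has not been measured. It differs from compound 3 by 4-formylphenyl in place of 3-methylphenyl on an aromatic carbon. For the measured compounds named here, no measured step covers this exchange: the one step in hand, a number 17.5 percentage points lower from compound 2 to compound 3 (beyond the scatter), concerns 3-methylphenyl in place of 4-ethylphenyl, not a formyl group. The nearest guide is compound 1, which also carries a 4-formylphenyl but differs from compound 4 elsewhere; compound 1 gives 25.3% against compound 3 at 28.4%, and these two values sit within the scatter. On that basis no step beyond the scatter is expected. The expected step is a number 1.4 percentage points lower from compound 3 to compound 4 (within the scatter). Compound 4 is estimated at 27% in this assay, with a range from 14% to 40%.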

Compound 4, a percentage reported as inhibition, at one concentration (the size of the read-out at that concentration, not a potency): 25.3%
Compound 4: the middle estimate sits 1.7 percentage points above what was measured; the measured number falls inside the stated range.
By their numbers in this assay, from the lowest: compounds 1, 4 and 3 (each within the scatter of the next); then compound 2.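

Working notes on the aryl position, on the aromatic carbon next to the ring nitrogen. In this assay, 4-formylphenyl in place of 3-methylphenyl gives a number 3.1 percentage points lower from compound 3 to compound 4 (within the scatter), so this position accepts a formyl-bearing aryl group with no readable shift from the 3-methylphenyl compound. With benzyl held on the ring nitrogen, formyl in place of ethyl gives a number 20.6 percentage points lower from compound 2 to compound 4 (beyond the scatter), which shows that compound 2, with its 4-ethylphenyl, stands apart from both compound 3 and compound 4 and that the earlier gap was not peculiar to the 3-methylphenyl group. Among the compounds shown here, the first reading at the ring nitrogen with the aryl group held fixed, benzyl in place of cyclohexyl, gives no change at the digits printed from compound 1 to compound 4 (within the scatter), so that exchange shows no effect in the 4-formylphenyl setting.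

No supporting data are available to account for the position of compound 2.

Compounds 2 and 3 differ in both the alkyl group and its place on the phenyl ring, so a 4-methylphenyl or a 3-ethylphenyl would be needed to separate the two, and a 4-propylphenyl would test a longer chain. As far as these compounds go, it also remains open whether an amine or a carboxylic acid on the phenyl ring would move the number, and whether cyclohexyl and benzyl would still match with 4-ethylphenyl in place.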